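Basic pyridinylmethylamine in place of a lactam on trypsin

The source may hold more compounds than are shown below. What is called first, only, known or untested is meant among the compounds shown, and "the series" means these compounds.

This account follows two aminobenzoxazole carboxamides and the methyl-substituted relative from which the series branches. Compound 1 `Cc1nn(-c2cccc(CN)c2)c2c(F)c(-c3ccc(N4CCCCC4=O)cc3)ccc12` in an assay on isolated protein for inhibition of Trypsin (Homo sapiens) (a higher number here means a weaker inhibitor, a lower number a stronger inhibitor), gives 1900 nM. Compound 2 `NC(=O)c1nn(-c2ccc3onc(N)c3c2)c2c(F)c(-c3ccc(N4CCCCC4=O)cc3F)ccc12` in this assay gives only > 10000 nM, which is a limit of the assay and not a number. So compound 2 stands at the limit of > 10000 nM in this assay, at which 1 of the 2 values shown sits, and no step between compound 1 and compound 2 can be sized from what is shown; their two values show only that compound 1 sits at a measured number while compound 2 does not.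

Compound 3 `CN(C)Cc1cnccc1-c1ccc(-c2ccc3c(C(N)=O)nn(-c4ccc5onc(N)c5c4)c3c2F)c(F)c1` is not yet measured. It differs from compound 2 in one place: 3-((dimethylamino)methyl)pyridin-4-yl in place of 2-oxopiperidin-1-yl on an aromatic carbon. Going by the values given here, no measured step exists for a change of this kind here, so the expectation rests on compound 2 alone. Compound 3 is expected to return into the measurable range of this assay, by a step of about an at least 1.4-fold lower number from compound 2 to compound 3 (0.15 log units; that floor lies within the scatter), since a limit leaves the true value of compound 2 open. For compound 3 the estimate in this assay is 7000 nM, expected to lie between 1500 nM and 30000 nM.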

Compound 3, inhibition constant: > 10000 nM
Compound 3 gave a limit, no number; the forecaster's own chance of this, stated with the estimate: 45%; at least 1.4-fold (0.15 log units) between middle value and limit.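

In this assay compound 3 gives > 10000 nM which is a limit of the assay and not a number. Compound 2 also stands at a limit, so no step between compound 2 and compound 3 can be read: the limit of > 10000 nM in this assay, at which 2 of the 3 values shown sit.

The compounds shown leave open the true values of compound 2 and compound 3, and so whether 3-((dimethylamino)methyl)pyridin-4-yl in place of 2-oxopiperidin-1-yl changes the value at all.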